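Aryl swap on the amide of compound 2

The compounds below may be only part of what the source reports. "The series", "measured", "known", "first", "only" and "open" are said of these compounds alone.

Working notes on the series. Among the compounds with values here, compound 2 `CCc1ccc(C(=O)NC[C@H]2c3[nH]c4ccccc4c3C[C@H]3[C@H]4c5[nH]c6ccccc6c5C[C@@H]([C@H](C#N)N23)N4C)cc1` stands at the higher of the two numbers measured so far: in a functional assay on HepG2 cells (Homo sapiens) for cytotoxicity, read by MTT assay, with a stated time of 72 h (on this read-out higher numbers stand for weaker inhibition and lower numbers for stronger inhibition), compound 2 gives 570 nM. Compound 1 `CN1[C@@H]2c3[nH]c4ccccc4c3C[C@H]1[C@H](C#N)N1[C@@H](CN3C(=O)c4ccccc4C3=O)c3[nH]c4ccccc4c3C[C@@H]21` in this assay gives 20 nM. Within the data shown here, the only measured step, a 29-fold higher number from compound 1 to compound 2 (1.45 log units; beyond the scatter), exchanged the whole substituent on the saturated chain carbon, including the linkage to it, so it is a large step but not one of the same kind as the change now in hand.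

Compound 3 `CN1[C@@H]2c3[nH]c4ccccc4c3C[C@H]1[C@H](C#N)N1[C@@H](CNC(=O)c3ccc4ccccc4n3)c3[nH]c4ccccc4c3C[C@@H]21` differs from compound 2 by quinolin-2-yl in place of 4-ethylphenyl on a carbonyl carbon. The amide linkage is kept; only the aromatic part on its carbonyl carbon is exchanged. Among the measured compounds shown here, no measured pair varies this part while holding the linkage, so the data give no direction for the change, and the one measured step says nothing about its size. The expectation is therefore a step of a 1.3-fold lower number from compound 2 to compound 3 (0.10 log units; within the scatter), held within the usual scatter, with wide uncertainty in both directions. On that basis compound 3 is estimated at 450 nM in this assay, expected to fall between 100 nM and 2000 nM.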

Compound 3, half-maximal inhibitory concentration: 110 nM
For compound 3 the middle estimate is 4.1-fold (0.61 log units) above the measured one, and the stated range covers the measured number.
By their numbers in this assay, from the lowest: compound 1; then compound 3; then compound 2.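

With the amide linkage held, the aromatic part on the carbonyl carbon proves able to move the number on its own in this assay: quinolin-2-yl in place of 4-ethylphenyl gives a 5.2-fold lower number from compound 2 to compound 3 (0.71 log units; beyond the scatter). The earlier step, a 29-fold higher number from compound 1 to compound 2 (1.45 log units; beyond the scatter), exchanged the whole substituent together with its linkage, so it could not show what this aromatic part contributes when the amide stays in place. The new step also exchanges several features at once, with a second aromatic ring, a ring nitrogen and a hydrogen-bond acceptor entering as the ethyl group leaves, and no available evidence accounts for the change in the number.

The compounds shown leave open which of these features carries the step, a question that a naphthyl group, with carbon-only rings, and a pyridyl group, with a single ring holding nitrogen, on the same carbonyl carbon could help to separate. Also open, from the compounds shown here alone, is whether the step from 4-ethylphenyl depends on the ethyl group, which an unsubstituted phenyl group on that carbonyl carbon would address.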